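Aryl thioether imidazolines: ester for isopropyl at prostacyclin receptor

This account rests on a few compounds, and the source may have more. Where it says the series, first, only, none or still open, it means among the compounds named here.

Compound 1 `Clc1ccc(Sc2ccc(NC3=NCCN3)cc2)cc1`: 79.4 nM
Compound 2 `CCOc1ccc(Sc2ccc(NC3=NCCN3)cc2)cc1`: 39.8 nM
Compound 3 `CC(C)c1ccc(Sc2ccc(NC3=NCCN3)cc2)cc1`: 251 nM

In an assay (Rattus norvegicus) for binding affinity to prostacyclin receptor (Homo sapiens), read by radioligand binding (a higher number here means a weaker inhibitor, a lower number a stronger inhibitor), compound 3 gives the highest number of the three; the nearest is compound 1 and the furthest compound 2, with a 3.2-fold higher number from compound 1 to compound 3 (0.50 log units; beyond the scatter) and a 6.3-fold higher number from compound 2 to compound 3 (0.80 log units; beyond the scatter) both beyond the scatter. Between compound 1 and compound 2 there is a 2.0-fold lower number from compound 1 to compound 2 (0.30 log units; within the scatter), within the scatter.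

Compound 4 `CCOC(=O)c1ccc(Sc2ccc(NC3=NCCN3)cc2)cc1` differs from compound 3 by ethoxycarbonyl in place of isopropyl on an aromatic carbon. The two steps that bear on it are those into isopropyl; both carry a higher number, and the ethoxy of compound 2 gives the lowest value. Replacing isopropyl with an oxygen-bearing group is therefore expected to lower the number in this assay by a modest step, a 3.1-fold lower number from compound 3 to compound 4 (0.50 log units; beyond the scatter). For compound 4 the estimate is 80 nM, expected between 25 nM and 250 nM.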

Compound 4, inhibition constant: 50.1 nM
Beside the measured number, compound 4's estimate is 1.6-fold (0.20 log units) above it; the range from low to high includes it.
By their numbers in this assay, from the lowest: compounds 2, 4 and 1 (each within the scatter of the next); then compound 3.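

In this assay, for the compounds shown here, ethoxycarbonyl at this position restores the number lost with isopropyl, a 5.0-fold lower number from compound 3 to compound 4 (0.70 log units; beyond the scatter), leaving isopropyl the only one of the four groups set apart beyond the scatter. Ethoxycarbonyl cannot be told from ethoxy, a 1.3-fold higher number from compound 2 to compound 4 (0.10 log units; within the scatter), or from chloro, a 1.6-fold lower number from compound 1 to compound 4 (0.20 log units; within the scatter). Oxygen in the group is thus not required, as chloro carries none.

Still open, on these data alone, is whether a carboxylic acid, an amide or a longer ester at this position would keep the number. No measurement at hand accounts for the isopropyl result.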